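A Longer Chain on the Shared Core of Compound 1

The source may report more compounds than this note shows. Statements on the series, on what has been measured and on what is new or still open speak of the compounds shown alone.

For the measured compounds named here, compound 1, `Cc1ccc(NC(=O)Nc2ccc(Oc3cc(/N=C/N(C)C)ncn3)cc2)cc1C(F)(F)F`, is the only member of this small set with a number in a functional assay on BaF3 cells (Mus musculus) for inhibition, read by CCK-8 assay, with a stated time of 72 h; on this read-out higher numbers stand for weaker inhibition of growth and lower numbers for stronger inhibition of growth: there compound 1 gives 6610 nM. Compound 2, `CNCCN(C)c1cc(Oc2ccc(NC(=O)Nc3ccc(C)c(C(F)(F)F)c3)cc2)ncn1`, differs from compound 1 in one place. In this assay compound 2 reaches only a limit of the assay, > 10000 nM. The step of an at least 1.5-fold higher number from compound 1 to compound 2 (0.17 log units; that floor lies within the scatter) is thus only a floor, and the limit of > 10000 nM in this assay, at which 1 of the 2 values shown sits, shows where that reading sits. Compound 3, `Cc1ccc(NC(=O)Nc2ccc(Oc3cc(N(C)CCN(C)C)ncn3)cc2)cc1C(F)(F)F`, is not yet measured; it differs from compound 1 by a group of 7 heavy atoms (5 carbon, 2 nitrogen; no ring) in place of a group of 5 heavy atoms (3 carbon, 2 nitrogen; no ring), on an aromatic carbon. Going by the values given here, the one measured step that bears on this change, an at least 1.5-fold higher number from compound 1 to compound 2 (0.17 log units; that floor lies within the scatter), points, if anywhere, toward a higher number, and its true size is unknown. Compound 3 is therefore expected to show a 1.8-fold higher number from compound 1 to compound 3 (0.26 log units; within the scatter), with a fair chance that this assay again reports only a limit. The estimate for compound 3 in this assay is 12000 nM, within 4000 nM to 30000 nM.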

Compound 3, concentration for 50% growth inhibition: 9410 nM
Compound 3: middle estimate off by 1.3-fold (0.11 log units), on the high side, and the stated range covers the measured number.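

For the compounds shown here, with the (2-(dimethylamino)ethyl)(methyl)amino chain on this aromatic carbon, compound 3 gives a full number rather than a limit in this assay, and the step of a 1.4-fold higher number from compound 1 to compound 3 (0.15 log units; within the scatter) sizes the change for the first time. At this position, next to the ring nitrogen, the exchange of the group in compound 1 for this chain therefore leaves the reading within the usual scatter, which the floor from the earlier pair could not show. Compound 2 stands at a limit of the assay. The step of an at least 1.0-fold lower number from compound 2 to compound 3 (0.02 log units; that floor lies within the scatter) for methyl in place of hydrogen on an amine nitrogen is therefore only a floor, and its true size cannot be read: the limit of > 10000 nM in this assay, at which 1 of the 3 values shown sits.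

From the compounds shown here alone, whether a primary amine or a hydroxyethyl chain at this position would move the number beyond the scatter from compound 1 stays open. Also open, going by these compounds, is how far the number of compound 2 lies past its limit.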